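The source may hold more compounds than are shown below. What is called first, only, known or untested is meant among the compounds shown, and "the series" means these compounds.

- compound 1 `O=C1C(=Cc2cccc(Cl)c2)C(=O)N(c2ccc(Cl)cc2)N1c1ccc(Cl)cc1`: 22600 nM
- compound 2 `O=C1C(=Cc2ccc(F)cc2F)C(=O)N(c2ccc(Cl)cc2)N1c1ccc(Cl)cc1`: 13100 nM

Of the two compounds measured in a functional assay on ECa-109 cells (Homo sapiens) for cytotoxicity, read by MTT assay, with a stated time of 72 h (a lower number here means a stronger inhibitor, a higher number a weaker inhibitor), compound 2 at 13100 nM sits within the scatter of compound 1. Compound 3 `O=C1C(=Cc2ccco2)C(=O)N(c2ccc(Cl)cc2)N1c1ccc(Cl)cc1` keeps the shared core but changes the ring on the chain: furan-2-yl in place of 2,4-difluorophenyl on a double-bonded chain carbon bound to a double-bonded ring carbon. Among the compounds with values here, only one measured step touches this place: a 1.7-fold lower number from compound 1 to compound 2 (0.24 log units; within the scatter). Within the data shown here, that step swapped one six-membered ring for another, and no measured compound carries a five-membered ring there, so it is only a rough guide. The expected change is none beyond the scatter: a 1.4-fold higher number from compound 2 to compound 3 (0.14 log units; within the scatter). For compound 3 the estimated value is 18000 nM, with an expected range from 7000 nM to 45000 nM.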

Compound 3, half-maximal inhibitory concentration: 14300 nM
Compound 3: middle estimate off by 1.3-fold (0.10 log units), on the high side; the measured number falls inside the stated range.
By their numbers in this assay, from the lowest: compounds 2, 3 and 1 (each within the scatter of the next).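

In this assay the furan-2-yl ring gives a 1.1-fold higher number from compound 2 to compound 3 (0.04 log units; within the scatter) and also a 1.6-fold lower number from compound 1 to compound 3 (0.20 log units; within the scatter) at this place, on a double-bonded chain carbon bound to a double-bonded ring carbon. A five-membered aromatic ring with an oxygen atom therefore stands in for either six-membered aromatic ring without a change beyond the scatter, which the two earlier compounds could not show. No measurement offers an explanation for this result. On these data alone, all three compounds carry an aromatic ring here, so whether a ring bearing an amine or a carboxylic acid would shift the number stays open.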